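Swapping fluorine for chlorine on the aryl ring

The source may hold more compounds than are shown below. What is called first, only, known or untested is meant among the compounds shown, and "the series" means these compounds.

Among the compounds with values here, compound 2 `Nc1ncnn2c([C@@H]3O[C@H](CO)[C@@H](O)[C@H]3O)cc(-c3ccc(F)cc3)c12` is the only compound with a number in a functional assay on HL-60 cells (Homo sapiens) for antiproliferative activity, with a stated time of 72 h; on this read-out lower numbers stand for stronger inhibition and higher numbers for weaker inhibition: compound 2 gives 68300 nM. Compound 1 `Nc1ncnn2c([C@@H]3O[C@H](CO)[C@@H](O)[C@H]3O)cc(-c3ccccc3)c12` reaches only a limit of the assay, > 100000 nM. Within the data shown here, the one measured step, an at least 1.4-fold lower number from compound 1 to compound 2 (0.16 log units; that floor lies within the scatter), rests on that limit of > 100000 nM in this assay, at which 1 of the 2 values shown sits, and does not decide a direction. Compound 3 `Nc1ncnn2c([C@@H]3O[C@H](CO)[C@@H](O)[C@H]3O)cc(-c3ccc(Cl)cc3)c12` carries chloro in place of fluoro on an aromatic carbon. Among the measured compounds shown here, no measured step swaps one halogen for another, so for compound 3 only a modest shift is expected, with a 1.7-fold lower number from compound 2 to compound 3 (0.23 log units; within the scatter) expected to land toward a somewhat lower number. Compound 3 is estimated at 40000 nM, with a range from 15000 nM to 120000 nM.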

Compound 3, half-maximal inhibitory concentration: 37900 nM
For compound 3 the middle estimate is 1.1-fold (0.02 log units) above the measured one; the range from low to high includes it.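

At this position, para to a large group, chloro in place of fluoro gives a 1.8-fold lower number from compound 2 to compound 3 (0.26 log units; within the scatter) in this assay, so the two halogens cannot be told apart here. Chloro in place of hydrogen gives an at least 2.6-fold lower number from compound 1 to compound 3 (0.42 log units; beyond the scatter), the first step in this set that lies beyond the scatter. That step is only a floor, since its starting point is a limit and not a number: the limit of > 100000 nM in this assay, at which 1 of the 3 values shown sits.

Going by these compounds, whether a larger halogen such as bromo would fit the same picture stays open. So does the effect of an amine or a carboxylic acid at this position.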